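A Third Methoxy Group on the Benzyl Ring of Compound 3

The compounds below may be only part of what the source reports. "The series", "measured", "known", "first", "only" and "open" are said of these compounds alone.

Three compounds have been measured in a functional assay on K562 cells (Homo sapiens) for antiproliferative activity, read by MTT assay, with a stated time of 48 h; on this read-out higher numbers stand for weaker inhibition of growth and lower numbers for stronger inhibition of growth:

Compound 1, `COc1ccc(N(C)c2nc(Cl)nc3c2ncn3Cc2ccc(OC)c(OC)c2)cc1`, gives 27000 nM.
Compound 2, `COc1ccc(N(C)c2nc(Cl)nc3c2ncn3Cc2cc(OC)c(OC)c(OC)c2)cc1`, gives 41000 nM.
Compound 3, `COc1cc(Cn2cnc3c(Cl)nc(Cl)nc32)cc(OC)c1`, gives 4600 nM.

Compound 1 and compound 2 differ by a single change, (methoxy in place of hydrogen on an aromatic carbon), and in this assay this produced a 1.5-fold higher number from compound 1 to compound 2 (0.18 log units; within the scatter). Compound 3 carries a different core; how it differs from compound 1 is not broken down here, but its value stands beyond the scatter below both compound 1 and compound 2.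

Compound 4, `COc1cc(Cn2cnc3c(Cl)nc(Cl)nc32)cc(OC)c1OC`, has not yet been measured. It arises from compound 3 by methoxy in place of hydrogen on an aromatic carbon. Among the measured compounds shown here, this is the same kind of change as the one from compound 1 to compound 2, though the surroundings differ: in compound 2 the new group sits ortho to a methoxy group, meta to a large group and meta to a methoxy group, whereas in compound 4 it sits ortho to two methoxy groups and para to a large group. Because a 1.5-fold higher number from compound 1 to compound 2 (0.18 log units; within the scatter) lay within the scatter, a step of about a 1.3-fold higher number from compound 3 to compound 4 (0.12 log units; within the scatter) is expected from compound 3 to compound 4. Compound 4 is therefore estimated to give 6000 nM, most likely between 2500 nM and 14000 nM.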

Compound 4, concentration for 50% growth inhibition: 4300 nM
Beside the measured number, compound 4's estimate is 1.4-fold (0.14 log units) above it, within the range that was stated.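

The added methoxy does not move the number beyond the scatter in this assay, with a 1.1-fold lower number from compound 3 to compound 4 (0.03 log units; within the scatter), and the same change agrees across the two cores: the same change on two cores in this assay, a 1.5-fold higher number (0.18 log units; within the scatter) from compound 1 to compound 2 and a 1.1-fold lower number (0.03 log units; within the scatter) from compound 3 to compound 4, 1.6-fold (0.21 log units) apart, within the scatter of two such steps. Among the compounds shown here, the one step here that lies beyond the scatter belongs to a different place, chloro in place of (4-methoxyphenyl)(methyl)amino on an aromatic carbon, with a 9.5-fold lower number from compound 2 to compound 4 (0.98 log units; beyond the scatter). This shows that in these two pairs the methoxy change carries from one core to the other as a step within the scatter, but it rests on two pairs only and does not show that the same would hold on any further core or in any other test.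

The compounds shown leave open whether a different group at the carbon that takes the new methoxy in compound 4, such as an amine, a carboxylic acid or a longer alkoxy chain, would shift the number. They also leave open how other amines in place of the chloro of compound 4 would compare, since only one such pair is shown.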